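The source may report more compounds than this note shows. Statements on the series, on what has been measured and on what is new or still open speak of the compounds shown alone.

Measured compounds:
compound 1, `CCCC(=O)OCCCCOC(=O)c1ccc(C(=O)Nc2ccc3c(c2)C(C)(C)CCC3(C)C)cc1` — 23200 nM
compound 2, `CCCC(CCC)C(=O)OCCCCOC(=O)c1ccc(C(=O)Nc2ccc3c(c2)C(C)(C)CCC3(C)C)cc1` — > 1000000 nM
compound 3, `CCCC(=O)OCCCOC(=O)c1ccc(C(=O)Nc2ccc3c(c2)C(C)(C)CCC3(C)C)cc1` — 5750 nM

In a functional assay on NB-4 cells (Homo sapiens) for inhibition, read by MTT assay, with a stated time of 48 h (a higher number here means a weaker inhibitor, a lower number a stronger inhibitor), compound 3 gives 5750 nM, the lowest of the two numbers shown; its nearest neighbour is compound 1 with 23200 nM. The value of compound 2 is a limit of the assay, not a number (the limit of > 1000000 nM in this assay, at which 1 of the 3 values shown sits). Compound 4, `CCCC(CCC)C(=O)OCCCOC(=O)c1ccc(C(=O)Nc2ccc3c(c2)C(C)(C)CCC3(C)C)cc1`, differs from compound 3 in one place: 1-propylbutyl in place of propyl on a carbonyl carbon. The same change has been measured once before, on the longer chain: an at least 43-fold higher number from compound 1 to compound 2 (1.63 log units; beyond the scatter). That step was large, so a large rise in this assay is expected for compound 4 as well, estimated as a 70-fold higher number from compound 3 to compound 4 (1.84 log units; beyond the scatter). Compound 4 is therefore expected to give about 400000 nM, within the range 100000 nM to 2000000 nM.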

Compound 4, half-maximal inhibitory concentration: > 1000000 nM
Compound 4 ended at the assay's limit (the forecaster's own chance of this, stated with the estimate: 40%); middle value at least 2.5-fold (0.39 log units) away from the limit.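

In this assay the 1-propylbutyl group on this carbonyl carbon raises the number on the shorter chain as well, with an at least 170-fold higher number from compound 3 to compound 4 (2.24 log units; beyond the scatter) and an at least 43-fold higher number from compound 1 to compound 4 (1.63 log units; beyond the scatter). Compound 4 gives > 1000000 nM, which is a limit and not a number. The change thus goes the same way on both chains, though its size cannot be compared: the same change on two cores in this assay, an at least 43-fold higher number (1.63 log units; beyond the scatter) from compound 1 to compound 2 and an at least 170-fold higher number (2.24 log units; beyond the scatter) from compound 3 to compound 4; the limit leaves it open whether they differ.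

The step between compound 2 and compound 4 cannot be read, as both values are limits. Going by these compounds, it remains open whether a smaller branched group such as isopropyl, or a straight butyl chain, on this carbonyl carbon would stay clear of that limit.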